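A few compounds are considered here, and "the series" means these few. Any claim that something is new, unique, unknown or untested is made for them only; others in the source may bear on it.

Measured in a functional assay on A549 cells (Homo sapiens) for cytotoxicity, read by MTT assay, with a stated time of 72 h; a lower number here means a stronger inhibitor, a higher number a weaker inhibitor:
compound 1 `CN(C)Cc1ccc2nc(NC(=O)N/N=C/c3cn(Cc4ccccc4Cl)c4ccccc34)sc2c1` gives 1080 nM
compound 2 `Cc1ccc(Cn2cc(/C=N/NC(=O)Nc3nc4ccc(CN5CCC(C)CC5)cc4s3)c3ccccc32)cc1` gives 2180 nM
compound 3 `Cc1ccc(Cn2cc(/C=N/NC(=O)Nc3nc4ccc(CN(C)C)cc4s3)c3ccccc32)cc1` gives 1600 nM

Compound 4 `CC1CCN(Cc2ccc3nc(NC(=O)N/N=C/c4cn(Cc5ccccc5Cl)c5ccccc45)sc3c2)CC1` is not yet measured in this assay. It differs from compound 2 by 2-chlorophenyl in place of 4-methylphenyl on a saturated chain carbon bound to an aromatic nitrogen. The same change occurs once more among these compounds, taking compound 3 to compound 1: 2-chlorophenyl in place of 4-methylphenyl on a saturated chain carbon bound to an aromatic nitrogen, which gave a 1.5-fold lower number from compound 3 to compound 1 (0.17 log units; within the scatter). The two places are identical in wording, so this is the same change, not merely the same kind. The cores of compound 2 and compound 3 differ by 4-methylpiperidin-1-yl in place of dimethylamino on a saturated chain carbon bound to an aromatic carbon, with a 1.4-fold lower number from compound 2 to compound 3 (0.13 log units; within the scatter). Both measured steps lie within the scatter; only the values of compound 2 and compound 1 sit more than the scatter apart.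

For compound 4 the step from compound 2 is expected to be a 1.5-fold lower number from compound 2 to compound 4 (0.16 log units; within the scatter), because the same change gave a 1.5-fold lower number from compound 3 to compound 1 (0.17 log units; within the scatter) on the core of compound 3. Compound 4 is therefore estimated at 1500 nM, expected between 700 nM and 3200 nM.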

Compound 4, half-maximal inhibitory concentration: 3330 nM
The estimate for compound 4 lay 2.2-fold (0.35 log units) below the measured number, and the stated range ends below it.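

On the core of compound 2, 2-chlorophenyl in place of 4-methylphenyl gives a 1.5-fold higher number from compound 2 to compound 4 (0.18 log units; within the scatter), and the two cores do not separate for this change: the same change on two cores in this assay, a 1.5-fold lower number (0.17 log units; within the scatter) from compound 3 to compound 1 and a 1.5-fold higher number (0.18 log units; within the scatter) from compound 2 to compound 4, 2.3-fold (0.35 log units) apart, within the scatter of two such steps

4-Methylpiperidin-1-yl in place of dimethylamino gives a 3.1-fold higher number from compound 1 to compound 4 (0.49 log units; beyond the scatter), and this step also does not separate from its counterpart on the other core: the same change on two cores in this assay, a 1.4-fold lower number (0.13 log units; within the scatter) from compound 2 to compound 3 and a 3.1-fold lower number (0.49 log units; beyond the scatter) from compound 4 to compound 1, 2.3-fold (0.35 log units) apart, within the scatter of two such steps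

Neither change is shown to depend on the core, but with only two cores per change, transfer is not established either, and the 2-chlorophenyl change has no settled direction, as both of its steps lie within the scatter.

Among these compounds, only two aryl groups and two amines appear here. As far as these compounds go, an unsubstituted phenyl on the chain carbon bound to the aromatic nitrogen, or a morpholine on the chain carbon bound to the aromatic carbon, remains open.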